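The compounds below may be only part of what the source reports. "The series", "measured", "known", "first", "only" and "open" are said of these compounds alone.

Compounds measured in a functional assay on A549 cells (Homo sapiens) for inhibition, read by XTT assay, with a stated time of 48 h; a higher number here means a weaker inhibitor, a lower number a stronger inhibitor:
Compound 1, `COc1ccc(C(=O)/C(=C/c2ccc([N+](=O)[O-])cc2)CC(C)C)cc1`, gives > 100000 nM, which is a limit of the assay and not a number.
Compound 2, `COc1ccc(C(=O)/C(=C/c2ccc(Cl)cc2)CC(C)C)cc1`, gives > 100000 nM, again a limit of the assay.
Compound 3, `COc1ccc(C(=O)/C(=C/c2ccc(C(F)(F)F)cc2)CC(C)C)cc1`, gives > 100000 nM, likewise a limit of the assay.

Compound 3 thus stands at the limit of > 100000 nM in this assay, at which 3 of the 3 values shown sit. The three measured steps, a step that the two limits leave unreadable from compound 1 to compound 2, a step that the two limits leave unreadable from compound 1 to compound 3 and a step that the two limits leave unreadable from compound 2 to compound 3, all change the substituent on the aromatic carbon, and each of them is left unreadable by the two limits that bound it. Compound 4, `COc1ccc(C(=O)/C(=C/c2ccc(C(F)(F)F)cc2)CC2CCCCC2)cc1`, arises from compound 3 by cyclohexyl in place of isopropyl on a saturated chain carbon bound to a double-bonded chain carbon. For the measured compounds named here, none of the measured steps touches this saturated chain carbon, so no measured step bears directly on the change, and the values of compounds 1 to 3 give no direction for it. Going by the values given here, what can be said is that every compound so far sits at the limit. Compound 4 is therefore expected to give 100000 nM in this assay, within a range of 20000 nM to 300000 nM. The expected step from compound 3 is a number no higher from compound 3 to compound 4 (the limit leaves the size open), with the result most likely reported as a limit again.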

Compound 4, half-maximal inhibitory concentration: > 100000 nM
Compound 4: only a limit was reported; the forecaster's own chance of this, stated with the estimate: 80%; the middle value sits exactly at the limit.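

For the compounds shown here, compound 4 gives > 100000 nM, which is a limit of the assay and not a number, and compound 3 sits at that same limit, so no step between the two can be read. The compounds shown leave open whether either the aromatic substituent or the chain group affects inhibition at all: the limit of > 100000 nM in this assay, at which 4 of the 4 values shown sit.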